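The compounds below may be only part of what the source reports. "The series", "measured", "known", "first", "only" and "open" are said of these compounds alone.

Compound 3 `Cc1cc(NC(=O)Nc2cccc(Cl)c2)c2ccccc2n1` gives 21000 nM in an ADME assay on HEK293 cells (Homo sapiens) for cytotoxicity, with a stated time of 72 h; a higher number here means that more compound is needed for the effect, a lower number that less compound is needed. Compound 2 `Cc1cc(NC(=O)Nc2ccc(Cl)cc2)c2ccccc2n1` gives only a limit, > 25000 nM, in this assay. Compound 1 `COc1cccc(NC(=O)Nc2cc(C)nc3ccccc23)c1` likewise gives only a limit, > 25000 nM. The core of compound 2 differs from the core of compound 3 as 4-chlorophenyl in place of 3-chlorophenyl on an amide-type nitrogen; that step is an at least 1.1-fold lower number from compound 2 to compound 3 (0.07 log units; that floor lies within the scatter). The change methoxy in place of chloro on an aromatic carbon gives an at least 1.1-fold higher number from compound 3 to compound 1 (0.07 log units; that floor lies within the scatter), a floor set by the limit of > 25000 nM in this assay, at which 2 of the 3 values shown sit. Compound 4 `COc1ccc(NC(=O)Nc2cc(C)nc3ccccc23)cc1` carries the same kind of change, (methoxy in place of chloro on an aromatic carbon), here para to a large group rather than meta to a large group. From compound 2, itself a limit, the step that the limit leaves unreadable from compound 2 to compound 4 is expected to be small, resting on an at least 1.1-fold higher number from compound 3 to compound 1 (0.07 log units; that floor lies within the scatter) and on (the limit of > 25000 nM in this assay, at which 2 of the 3 values shown sit). Compound 4 is therefore estimated at 30000 nM, within 15000 nM to 70000 nM, and is most likely to be reported again only as a limit.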

Compound 4, half-maximal effective concentration: > 25000 nM
Compound 4: a limit, no number; the forecaster's own chance of this, stated with the estimate: 75%; the middle value lies beyond the limit too.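

No step can be read between compound 2 and compound 4 in this assay, since both stand only as limits: the limit of > 25000 nM in this assay, at which 3 of the 4 values shown sit.

Left open is the size of methoxy in place of chloro para to a large group, and where compound 2 and compound 4 actually lie.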